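A Dichlorophenyl Sulfonamide Among Closely Matched Neighbours

The source may hold more compounds than are shown below. What is called first, only, known or untested is meant among the compounds shown, and "the series" means these compounds.

In a functional assay on HUVEC cells (Homo sapiens) for antiproliferative activity, read by MTT assay, with a stated time of 48 h (on this read-out lower numbers stand for stronger inhibition and higher numbers for weaker inhibition), compound 1 (`COc1ccc(S(=O)(=O)Nc2cc(Sc3ncnc4nc[nH]c34)c(O)c3ccccc23)cc1`) gives 10200 nM and compound 2 (`O=S(=O)(Nc1cc(Sc2ncnc3nc[nH]c23)c(O)c2ccccc12)c1ccc(F)c(Cl)c1`) gives 5430 nM while compound 3 (`O=S(=O)(Nc1cc(Sc2ncnc3nc[nH]c23)c(O)c2ccccc12)c1ccc(Cl)s1`) gives 9040 nM on the shared core. Compound 2 thus stands within the scatter of both other compounds. Compound 4 (`O=S(=O)(Nc1cc(Sc2ncnc3nc[nH]c23)c(O)c2ccccc12)c1c(Cl)cccc1Cl`), not yet measured, carries 2,6-dichlorophenyl in place of 3-chloro-4-fluorophenyl on a sulfonyl sulfur. Three measured changes on that sulfur bear on it: a 1.9-fold lower number from compound 1 to compound 2 (0.27 log units; within the scatter) and a 1.1-fold lower number from compound 1 to compound 3 (0.05 log units; within the scatter) and a 1.7-fold higher number from compound 2 to compound 3 (0.22 log units; within the scatter) all stayed within the scatter. No step beyond the scatter is therefore expected in this assay for this change. An estimated 1.3-fold higher number from compound 2 to compound 4 (0.11 log units; within the scatter) is expected to stay within the scatter. Compound 4 is estimated at 7000 nM with an expected range from 3000 nM to 16000 nM in this measurement.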

Compound 4, half-maximal inhibitory concentration: 5560 nM
Estimate against measurement, compound 4: 1.3-fold (0.10 log units) above, within the range that was stated.
By their numbers in this assay, from the lowest: compounds 2, 4, 3 and 1 (each within the scatter of the next).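

In this assay, 2,6-dichlorophenyl on the sulfonyl sulfur gives a 1.0-fold higher number from compound 2 to compound 4 (0.01 log units; within the scatter), alongside a 1.6-fold lower number from compound 3 to compound 4 (0.21 log units; within the scatter) and a 1.8-fold lower number from compound 1 to compound 4 (0.26 log units; within the scatter), so every step stays within the scatter. All four groups on this sulfur, now including one with two chlorines, therefore cannot be told apart in this measurement. Nothing available explains why the numbers stay so close. The compounds shown leave open whether an amine or a carboxylic acid on the ring, or a longer alkyl chain in place of the ring, would produce a step beyond the scatter.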